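Hydroxy to Methyl on the Side Chain of Compound 1

The source may hold more compounds than are shown below. What is called first, only, known or untested is meant among the compounds shown, and "the series" means these compounds.

Compound 1 `CN(CCO)/N=N/c1n[nH]cc1C(N)=O` was tested in a functional assay on L1210 cells (Mus musculus) for antiproliferative activity (on this read-out lower numbers stand for lower potency and higher numbers for higher potency (the scale is a negative logarithm)), and gives 3.1. Among the three measured compounds it stands second highest. Its nearest neighbour is compound 2 `CN(/N=N/c1ccc(C(N)=O)cc1)c1cccs1`, which in this assay gives 2.9, a value within the usual scatter of that of compound 1. Furthest away is compound 3 `CCCCN(C)/N=N/c1ccc(C(N)=O)cc1`, which in this assay gives 3.47, beyond the scatter above compound 1.

Compound 4 `CCCN(C)/N=N/c1n[nH]cc1C(N)=O` is not yet measured. It differs from compound 1 in one place: methyl in place of hydroxy on a saturated chain carbon, two bonds along the chain from an amine nitrogen.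

Going by the values given here, only one measured step exists, and it is on a different core: a number 0.57 log units higher from compound 2 to compound 3 (beyond the scatter). That step exchanges the whole group on the amine nitrogen, whereas the change to compound 4 is smaller and sits two bonds along the chain, so it bears on the present step only loosely. The expectation for this assay is therefore a small rise or no step beyond the scatter, expressed as a number 0.20 log units higher from compound 1 to compound 4 (within the scatter). Compound 4 is estimated at 3.3, within 2.85 to 3.8.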

Compound 4, logarithm of the reciprocal of the active concentration, log(1/C): 3.7
Compound 4: middle estimate off by 0.40 log units, on the low side; measured number inside the range.
By their numbers in this assay, from the lowest: compounds 2 and 1 (each within the scatter of the next); then compounds 3 and 4 (each within the scatter of the next).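

Going by these compounds alone, this is the first step read on the core of compound 1 itself: in this assay, methyl in place of hydroxy on a saturated chain carbon, two bonds along the chain from an amine nitrogen, gives a number 0.60 log units higher from compound 1 to compound 4 (beyond the scatter). The position is therefore not silent, since this read-out tells 2-hydroxyethyl and propyl apart on the same amine nitrogen, and the compound without the hydroxy has the higher number. No measurement here explains why the number rises.

From the compounds shown here alone, it remains open whether the rise comes from losing the hydroxy or from having the extra carbon, a question that a methoxy or an amine at the chain end, or a longer chain, could help to settle. Going by these compounds, whether the same exchange acts alike on the core of compound 3 is also open.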